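The source may hold more compounds than are shown below. What is called first, only, known or untested is meant among the compounds shown, and "the series" means these compounds.

Measured so far:
compound 1, `CC(C)(O)CN1CCC(Oc2ccc([C@H]3CC[C@]4(CC3)OOC3(O4)C4CC5CC(C4)CC3C5)cc2)CC1`, 1810 nM in an ADME assay on the whole organism (strain FVB) for pharmacokinetics, with Mus musculus as the target, read by LC-MS, at a dose of 30 mg/kg by the oral route; a higher number here means more compound in the circulation at the dose given, a lower number less compound in the circulation
compound 2, `CC(C)(O)CNCCCOc1ccc([C@H]2CC[C@]3(CC2)OOC2(O3)C3CC4CC(C3)CC2C4)cc1`, 1210 nM

Compound 1 holds the highest of the two numbers, and the step of a 1.5-fold lower number from compound 1 to compound 2 (0.17 log units; within the scatter) lies within the scatter. Compound 3, `NCCCCOc1ccc([C@H]2CC[C@]3(CC2)OOC2(O3)C3CC4CC(C3)CC2C4)cc1`, is not yet measured; it differs from compound 1 by 4-aminobutyl in place of 1-(2-hydroxy-2-methylpropyl)piperidin-4-yl on an oxygen on an aromatic ring. Going by the values given here, the one measured step that bears on it, a 1.5-fold lower number from compound 1 to compound 2 (0.17 log units; within the scatter), also replaces the ring with an open chain and changed little. A step of similar size, not beyond the scatter, is therefore expected: a 1.5-fold lower number from compound 1 to compound 3 (0.18 log units; within the scatter). For compound 3 the estimate is 1200 nM, ranging from 450 nM to 3200 nM.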

Compound 3, maximal plasma concentration: 370 nM
For compound 3 the middle estimate is 3.2-fold (0.51 log units) above the measured one; measured number outside the range, below it.
By their numbers in this assay, from the lowest: compound 3; then compounds 2 and 1 (each within the scatter of the next).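

In this assay this position proves less forgiving than the first pair suggested: 4-aminobutyl gives a 4.9-fold lower number from compound 1 to compound 3 (0.69 log units; beyond the scatter) and also a 3.3-fold lower number from compound 2 to compound 3 (0.51 log units; beyond the scatter) in this comparison. An open chain alone therefore does not settle the outcome, since compound 2 keeps the 2-hydroxy-2-methylpropyl group and compound 3 does not. No evidence on the reason is at hand. Still open, on these data alone, is whether that group or the chain matters: a 4-aminobutyl chain carrying 2-hydroxy-2-methylpropyl on its amine, or a piperidin-4-yl group with a free ring amine, would separate the two.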